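A Methyl Added to a Pyridazinone Carboxamide: What to Expect

A few compounds are considered here, and "the series" means these few. Any claim that something is new, unique, unknown or untested is made for them only; others in the source may bear on it.

Measured compounds:
- compound 1, `Cc1ccc(-n2nc(C(=O)Nc3ccc(Oc4ncnc5ccsc45)cc3)c(C)cc2=O)cc1`: 25000 nM
- compound 2, `Cc1ccc(-n2nc(C(=O)Nc3ccc(Oc4ncnc5ccsc45)cc3)c(C)cc2=O)c(C)c1`: 17900 nM
- compound 3, `O=C(Nc1ccc(Oc2ncnc3ccsc23)c(F)c1)c1nn(-c2ccccc2)ccc1=O`: 13500 nM

All three compounds were tested in a functional assay on HepG2 cells (Homo sapiens) for cytotoxicity, read by MTT assay, with a stated time of 72 h (a higher number here means a weaker inhibitor, a lower number a stronger inhibitor), and all three gave numbers that lie close together; none of their gaps reaches beyond the scatter of repeated measurements, so no order can be read among them. The difference between the core of compound 1 and the core of compound 3 is not broken down here.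

From compound 1 to compound 2 the change is methyl in place of hydrogen on an aromatic carbon, and in this assay it made a 1.4-fold lower number from compound 1 to compound 2 (0.15 log units; within the scatter).

Compound 4, `Cc1ccc(-n2ccc(=O)c(C(=O)Nc3ccc(Oc4ncnc5ccsc45)c(F)c3)n2)cc1`, has not yet been measured. It differs from compound 3 by methyl in place of hydrogen on an aromatic carbon. Going by the values given here, this is the same kind of change as the one from compound 1 to compound 2, though the surroundings of the place differ: in compound 2 the methyl sits ortho to a large group and meta to a methyl group, whereas in compound 4 it sits para to a large group.

Because the earlier step was a 1.4-fold lower number from compound 1 to compound 2 (0.15 log units; within the scatter), compound 4 is expected to sit near compound 3, with a step of about a 1.2-fold lower number from compound 3 to compound 4 (0.09 log units; within the scatter). For compound 4 in this assay the estimate is 11000 nM, with a likely range from 4500 nM to 27000 nM.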

Compound 4, half-maximal inhibitory concentration: 24300 nM
The estimate for compound 4 lay 2.2-fold (0.34 log units) below the measured number; measured number inside the range.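

In this assay, placing the methyl on the phenyl ring, which turns phenyl into 4-methylphenyl, gave a 1.8-fold higher number from compound 3 to compound 4 (0.26 log units; within the scatter). Set beside the earlier case of this change, the two results cannot be told apart: the same change on two cores in this assay, a 1.4-fold lower number (0.15 log units; within the scatter) from compound 1 to compound 2 and a 1.8-fold higher number (0.26 log units; within the scatter) from compound 3 to compound 4, 2.5-fold (0.40 log units) apart, within the scatter of two such steps. This means the data give no sign that the core alters what this methyl does, but they do not show that its effect carries from one core to the other, since neither step can be separated from the differences expected when a single compound is simply tested again, and so no effect of the methyl can be claimed on either core.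

The compounds shown leave open whether a different group at this place on the ring, such as an amine, a carboxylic acid or a longer chain, would give a step beyond the scatter. They also leave open whether such a step would be similar on both cores, a question that can only be tested with a change large enough to be read clearly on each of them.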